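Notes on an aryl exchange and microsomal clearance

A few compounds are considered here, and "the series" means these few. Any claim that something is new, unique, unknown or untested is made for them only; others in the source may bear on it.

Among the compounds with values here, compound 2 `CC(C)n1cc(-c2cc(C(O)(C(F)(F)F)C(F)(F)F)cnc2N2CCN(S(=O)(=O)c3ccc(N)nc3)CC2)cn1` stands highest of the two numbers so far in an ADME assay (liver) for metabolic stability, with Liver microsome (Rattus norvegicus) as the target, using microsomes and NADPH, with a stated time of 30 min, tested at 1 uM (on this read-out higher numbers stand for fast clearance and lower numbers for slow clearance), where compound 2 gives 198 mL.min-1.g-1, while compound 1 `Nc1ccc(S(=O)(=O)N2CCN(c3ncc(C(O)(C(F)(F)F)C(F)(F)F)cc3C#CCCO)CC2)cn1` gives 68 mL.min-1.g-1; the only measured step is a 2.9-fold higher number from compound 1 to compound 2 (0.46 log units; beyond the scatter). Compound 3 `Nc1ccc(S(=O)(=O)N2CCN(c3ncc(C(O)(C(F)(F)F)C(F)(F)F)cc3-c3cncc(F)c3)CC2)cn1` differs from compound 2 by 5-fluoropyridin-3-yl in place of 1-isopropyl-1H-pyrazol-4-yl on an aromatic carbon. Within the data shown here, no measured step covers this exchange, and the one step known concerns a different group at the same place, so it gives little guidance. The step expected in this assay is a 1.5-fold lower number from compound 2 to compound 3 (0.18 log units; within the scatter), with a wide range. Compound 3 is estimated at 130 mL.min-1.g-1, between 50 mL.min-1.g-1 and 300 mL.min-1.g-1.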

Compound 3, intrinsic clearance in microsomes: 19 mL.min-1.g-1
For compound 3 the middle estimate is 6.8-fold (0.84 log units) above the measured one; measured number outside the range, below it.
By their numbers in this assay, from the lowest: compound 3; then compound 1; then compound 2.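

Within the data shown here, at this place on the core, the ring that enters matters far more in this assay than the single earlier step could show: 5-fluoropyridin-3-yl in place of 1-isopropyl-1H-pyrazol-4-yl gives a 10-fold lower number from compound 2 to compound 3 (1.02 log units; beyond the scatter). An aromatic ring here therefore does not go with fast clearance as such, and replacing 4-hydroxybut-1-yn-1-yl with the fluoropyridine gives a 3.6-fold lower number from compound 1 to compound 3 (0.55 log units; beyond the scatter), opposite in direction to the step to the pyrazole. No measurement bears on the cause of these steps.

The compounds shown do not separate the fluorine from the ring nitrogen of 5-fluoropyridin-3-yl. From the compounds shown here alone, how an amine such as morpholine or a carboxylic acid at this place would read remains open.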